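A few compounds are considered here, and "the series" means these few. Any claim that something is new, unique, unknown or untested is made for them only; others in the source may bear on it.

Measured in an assay on CHO cells for displacement of a labelled ligand from 5-hydroxytryptamine receptor 1D (Homo sapiens); a lower number here means a stronger inhibitor, a higher number a weaker inhibitor:

- compound 1 `O[C@H]1Cc2ccccc2C1NC1CCN(CCCc2c[nH]c3ccc(-n4cnnc4)cc23)CC1`: 37 nM
- compound 2 `CN(Cc1ccsc1)C1CCN(CCCc2c[nH]c3ccc(-n4cnnc4)cc23)CC1`: 1.5 nM
- compound 3 `CC(=O)Nc1ccc([C@@H](C)NCC2CCN(CCCc3c[nH]c4ccc(-n5cnnc5)cc34)CC2)cc1`: 1.5 nM

Compound 1 gives the highest of the three numbers in this assay; compound 2 and compound 3 both sit well below it, and their two values lie within the scatter of each other.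

Compound 4 `c1ccc2c(c1)CCC2NCC1CCN(CCCc2c[nH]c3ccc(-n4cnnc4)cc23)CC1` has not yet been measured. It differs from compound 1 at the saturated ring carbon of the shared core: ((2,3-dihydro-1H-inden-1-yl)amino)methyl in place of (2-hydroxy-2,3-dihydro-1H-inden-1-yl)amino on a saturated ring carbon. For the measured compounds named here, the one measured step that bears on a change at this position is a 25-fold lower number from compound 1 to compound 2 (1.39 log units; beyond the scatter), a large drop brought about by swapping out the same (2-hydroxy-2,3-dihydro-1H-inden-1-yl)amino group. Compound 3, which carries its amine through a methylene on that ring carbon, gives 1.5 nM, in the same low range as compound 2. On this basis a lower number is expected for compound 4 in this assay, though the size of the step is uncertain since the entering group keeps the indane of compound 1. The step expected is a 4.6-fold lower number from compound 1 to compound 4 (0.67 log units; beyond the scatter). The estimate for compound 4 is 8 nM, with a range from 2 nM to 30 nM.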

Compound 4, half-maximal inhibitory concentration: 1.1 nM
Compound 4: the middle estimate sits 7.3-fold (0.86 log units) above what was measured; the measured number lies below the stated range.
By their numbers in this assay, from the lowest: compounds 4, 2 and 3 (each within the scatter of the next); then compound 1.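

In this assay, the step of a 34-fold lower number from compound 1 to compound 4 (1.53 log units; beyond the scatter) shows that the indane ring can stay at this saturated ring carbon and the number still falls, so the indane ring alone does not go with the high value of compound 1. The steps of a 1.4-fold lower number from compound 3 to compound 4 (0.13 log units; within the scatter) and a 1.4-fold lower number from compound 2 to compound 4 (0.13 log units; within the scatter) are both within the scatter, so the ((2,3-dihydro-1H-inden-1-yl)amino)methyl group matches the low values of two quite different groups. No measurement offered here accounts for this result.

This change removes the hydroxyl and adds a methylene in one step, so the share of each stays unresolved. On these data alone, a (2,3-dihydro-1H-inden-1-yl)amino group on the same ring carbon, or a hydroxyl-bearing indane on the aminomethyl link, would separate the two, and a longer chain in place of that methylene remains open too.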